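A few compounds are considered here, and "the series" means these few. Any claim that something is new, unique, unknown or untested is made for them only; others in the source may bear on it.

Compound 3 `CCc1oc2ccc(OC)cc2c1C(=O)c1cc(Br)c(O)c(Br)c1`: 99.9%
Compound 2 `CCc1cc2c(C(=O)c3ccc(OC)cc3)cc(O)cc2o1`: 12.4%
Compound 1 `CCc1oc2cc(OC)ccc2c1C(=O)c1ccc(OC)cc1`: 6.2%

In an assay for inhibition of solute carrier family 22 member 12 (Homo sapiens), read by scintillation counting, with a stated time of 60 min, tested at 50 uM (on this read-out lower numbers stand for less inhibition and higher numbers for more inhibition at the one concentration tested (going by the name of the read-out)), compound 3 stands highest of the three numbers; compound 2 comes nearest, its value lying beyond the scatter below it, and compound 1 lies furthest, also beyond the scatter. Compound 4 `CCc1oc2ccc(O)cc2c1C(=O)c1cc(Br)c(O)c(Br)c1` has not yet been measured. It differs from compound 3 in one place: hydrogen in place of methyl on an oxygen on an aromatic ring. Among the measured compounds shown here, no pair of measured compounds carries this single change, so the size of the step is open. Since compound 3 already gives 99.9% in this assay, a number near the top of the scale, the step is expected to be small, at most a modest move downward and likely within the scatter: a number 4.9 percentage points lower from compound 3 to compound 4 (within the scatter). Compound 4 is therefore estimated at 95%, with a range from 75% to 100%.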

Compound 4, a percentage reported as inhibition, at one concentration (the size of the read-out at that concentration, not a potency): 99.9%
Compound 4: middle estimate off by 4.9 percentage points, on the low side; low and high end bracket the measured number.
By their numbers in this assay, from the lowest: compounds 1 and 2 (each within the scatter of the next); then compounds 3 and 4 (each within the scatter of the next).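

In this assay, going from methoxy to hydroxy on an oxygen on an aromatic ring gives no change at the digits printed from compound 3 to compound 4 (within the scatter), so at the one concentration tested the read-out does not depend on this methyl. Both compounds lie near the top of the scale, however, so this single concentration cannot show whether a difference in potency lies hidden there. Nothing measured here accounts for this result.

As far as these compounds go, what an ethoxy group, a longer chain ending in a carboxylic acid or an amine would do at this oxygen stays open. From the compounds shown here alone, whether the same change holds at lower concentrations also stays open.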